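This account rests on a few compounds, and the source may have more. Where it says the series, first, only, none or still open, it means among the compounds named here.

Among the compounds with values here, in a functional assay on HCT-116 cells (Homo sapiens) for antiproliferative activity, read by MTT assay, with a stated time of 48 h (a lower number here means a stronger inhibitor, a higher number a weaker inhibitor), compound 2 (`CCCCCCCC(CCO)n1cnc2c(Cl)nc(Cl)nc21`) gives 12800 nM, the only true number measured so far. Compound 1 (`CCCCCCC(CCO)n1cnc2c(N)nc(Cl)nc21`), which also carries an amino group on the core, gives > 50000 nM, and this value is a limit of the assay, not a number. The next compound, compound 3 (`CCCCCCCC(CCO)n1cnc2c(N)nc(Cl)nc21`), has amino in place of chloro on an aromatic carbon, next to the ring nitrogen: amino in place of chloro on an aromatic carbon. Within the data shown here, no measured pair shows this swap directly, so the size of the step is a judgement. The limit reached by compound 1 at > 50000 nM suggests that the amino group will not help in this assay. A move towards weaker inhibition is expected, with the estimated step of a 3.1-fold higher number from compound 2 to compound 3 (0.49 log units; beyond the scatter). The result could well reach the assay limit. For compound 3 the expected value is 40000 nM, with an estimated range of 16000 nM to 100000 nM.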

Compound 3, half-maximal inhibitory concentration: > 50000 nM
Compound 3 ended at the assay's limit; the forecaster's own chance of this, stated with the estimate: 50%; middle value at least 1.2-fold (0.09 log units) from the limit.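

Swapping chloro for amino on this aromatic carbon, next to the ring nitrogen, gives in this assay an at least 3.9-fold higher number from compound 2 to compound 3 (0.59 log units; beyond the scatter). Within the data shown here, this is the first pair that differs in this one place alone, so the effect of the swap can now be read directly, with amino giving the weaker inhibitor rather than this being only suggested by compound 1. The step from compound 1 to compound 3, methyl in place of hydrogen on the chain, cannot be read, and the same limit means the step above gives only a lowest size, not a full one: the limit of > 50000 nM in this assay, at which 2 of the 3 values shown sit.

Still open, as far as these compounds go, is whether a methoxy group or a methylamino group on this carbon would give a lower number than compound 2 does. Also open, from the compounds shown here alone, is how a longer chain would change the number when chloro stays in place.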